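This account rests on a few compounds, and the source may have more. Where it says the series, first, only, none or still open, it means among the compounds named here.

Measured so far in an ADME assay on Vero cells (Chlorocebus sabaeus) for cytotoxicity, read by WST assay; on this read-out lower numbers stand for higher toxicity in this test and higher numbers for lower toxicity in this test:
compound 1, `O=c1[nH]c(Nc2ccc(F)c(F)c2F)nc2cc(Cl)ccc12`, > 25000 nM.
compound 2, `O=c1[nH]c(Nc2cccc(F)c2)nc2cc(Cl)ccc12`, > 25000 nM.

Each of these readings is a limit of the assay, not a number. Compound 2 thus stands at the limit of > 25000 nM in this assay, at which 2 of the 2 values shown sit, together with compound 1, and whether the two differ cannot be told from these readings. Compound 3, `O=c1[nH]c(Nc2cc(F)cc(F)c2)nc2cc(Cl)ccc12`, differs from compound 2 by fluoro in place of hydrogen on an aromatic carbon. Among the compounds with values here, no step between measured compounds is available, so no change beyond the scatter is expected from this substitution in this assay. Compound 3 is therefore expected to sit at 30000 nM, with a range from 15000 nM to 80000 nM. The step that the limit leaves unreadable from compound 2 to compound 3 is expected to be none beyond the scatter.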

Compound 3, half-maximal cytotoxic concentration: >= 18000 nM
Compound 3: only a limit was reported; the forecaster's own chance of this, stated with the estimate: 85%; the middle value is on the limit's open side.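

In this assay, within the data shown here, compound 2 and compound 3 are both reported only as limits, so no step between them can be read. The compounds shown leave open where the true value of any of them lies.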